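A few compounds are considered here, and "the series" means these few. Any claim that something is new, unique, unknown or untested is made for them only; others in the source may bear on it.

Working notes on the series.

Three compounds carry measured values in a physicochemical assay for solubility, in phosphate buffer, with a stated time of 18 h; a lower number here means a less soluble compound, a higher number a more soluble compound. Compound 1 `CC(C)(C)c1nc(-c2ccc[nH]2)c2cc(C(N)=O)c(N)nc2n1` gives 130000 nM. Compound 2 `N#Cc1c(N)nc2nc(C3CC3)ncc2c1N` gives 23000 nM. Compound 3 `CC(C)(C)c1nc(-c2cccs2)c2c(N)c(C#N)c(N)nc2n1` gives 56000 nM, which places it second highest of the three; compound 1 sits above it by a margin beyond the usual scatter, and compound 2 sits below it by a margin also beyond the scatter. No two of these compounds differ in a single place, so none of the gaps between them can be read as the effect of one change.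

The step followed here runs from compound 3 to compound 4 `CC(C)(C)c1nc(-c2ncn[nH]2)c2c(N)c(C#N)c(N)nc2n1`, which has not yet been measured in this assay. The change is 1H-1,2,4-triazol-5-yl in place of thiophen-2-yl on an aromatic carbon. Within the data shown here, the only anchor for this step is the value of compound 3 itself; the other two compounds share neither the same core substitution nor a single-point relation to compound 4.

Compound 4 is expected to give a somewhat higher number than compound 3 in this assay, the step from compound 3 being estimated at a 2.1-fold higher number from compound 3 to compound 4 (0.33 log units; beyond the scatter). The estimate for compound 4 is 120000 nM, with a range from 50000 nM to 300000 nM.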

Compound 4, solubility: 64500 nM
For compound 4 the middle estimate is 1.9-fold (0.27 log units) above the measured one, and the stated range covers the measured number.
By their numbers in this assay, from the lowest: compound 2; then compounds 3, 4 and 1 (each within the scatter of the next, the first and the last beyond it).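

In this assay, among these compounds, 1H-1,2,4-triazol-5-yl in place of thiophen-2-yl on an aromatic carbon gives a 1.2-fold higher number from compound 3 to compound 4 (0.06 log units; within the scatter), the first comparison that isolates a single place, and the two compounds cannot be told apart in this read-out. At this position, then, a five-membered aromatic ring with 3 hetero atoms, 1 hydrogen-bond donor and 2 hydrogen-bond acceptors takes the place of one with 1 hetero atom, 0 hydrogen-bond donors and 1 hydrogen-bond acceptor, with no step beyond the scatter on the shared core. No separate measurement is available to explain this result.

From the compounds shown here alone, this single pair gives no trend for the position, and what a carboxylic acid, a primary amine or a morpholine ring would do on the same aromatic carbon remains open. Among the compounds shown here, also open is whether the same exchange of rings would give a similar step on the core of compound 1 or on the core of compound 2, where no matched pair yet exists.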